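Swapping the aryl group on the pyrazole acid core

A few compounds are considered here, and "the series" means these few. Any claim that something is new, unique, unknown or untested is made for them only; others in the source may bear on it.

Two compounds share one core and differ only in the aryl group attached to an aromatic carbon of the five-membered ring with two nitrogens. Compound 1 `COc1ccc(-c2c(C)nn(-c3nc(-c4ccc(Cl)c(Cl)c4)c(SC(C)C)s3)c2C(=O)O)cc1` carries a 4-methoxyphenyl there and gives 2100 nM in a functional assay on BJAB cells (Homo sapiens) for antiproliferative activity, with a stated time of 4 days; a higher number here means that more compound is needed for the effect, a lower number that less compound is needed. Compound 2 `COc1cccc(-c2c(C)nn(-c3nc(-c4ccc(Cl)c(Cl)c4)c(SC(C)C)s3)c2C(=O)O)c1` carries a 3-methoxyphenyl instead and gives 14000 nM in this assay; the move is a 6.7-fold higher number from compound 1 to compound 2 (0.82 log units; beyond the scatter). Compound 2 thus stands with the highest number of the two, and its nearest neighbour is compound 1.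

Compound 3 `Cc1nn(-c2nc(-c3ccc(Cl)c(Cl)c3)c(SC(C)C)s2)c(C(=O)O)c1-c1ccccc1Cl` takes the next step: 2-chlorophenyl in place of 3-methoxyphenyl on an aromatic carbon. Among the measured compounds shown here, only the step from compound 1 to compound 2 bears on this, and it shows that the aryl group matters well beyond the scatter. It does not, however, show what a chlorine in place of a methoxy does, nor what the 2-position brings. Given that compound 1 with 2100 nM shows the same core can reach lower numbers, compound 3 is expected to land somewhere between the two, with a step of a 2.8-fold lower number from compound 2 to compound 3 (0.45 log units; beyond the scatter). The estimate for compound 3 in this assay is 5000 nM, in a range from 1000 nM to 25000 nM.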

Compound 3, half-maximal effective concentration: 13100 nM
Estimate against measurement, compound 3: 2.6-fold (0.42 log units) below; measured number inside the range.
By their numbers in this assay, from the lowest: compound 1; then compounds 3 and 2 (each within the scatter of the next).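

In this assay the exchange of 3-methoxyphenyl for 2-chlorophenyl gives a 1.1-fold lower number from compound 2 to compound 3 (0.03 log units; within the scatter) and so leaves the two groups unseparated at this position, even though the group that enters carries chlorine instead of the oxygen-bearing methoxy and differs in where its substituent is named on the ring. The second comparison gives a 6.2-fold higher number from compound 1 to compound 3 (0.80 log units; beyond the scatter) and shows that the gap seen earlier is not confined to the pair of methoxyphenyl compounds: among these three aryl groups, 4-methoxyphenyl is the only one whose number stands apart, and compound 1 has the lowest number, with both of its steps printed as beyond the scatter. No measurement accompanying these compounds accounts for the pattern.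

Since the chlorine and its place on the ring enter together, the shared core's three compounds cannot tell what each contributes alone. Also open, from the compounds shown here alone, is how the number would respond to an unsubstituted phenyl, a pyridine ring, or a phenyl carrying an amine or a trifluoromethyl group at this aromatic carbon.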